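A few compounds are considered here, and "the series" means these few. Any claim that something is new, unique, unknown or untested is made for them only; others in the source may bear on it.

Of the compounds shown here, three sharing one core have been tested in a functional assay on the whole organism (strain albino) for inhibition, with Rattus norvegicus as the target, read by paw edema, with stated times of 1 h and 2 h, at a dose of 20 mmol/kg by the intraperitoneal route; a higher number here means more inhibition at the dose given (going by the name of the read-out), a lower number less inhibition. Compound 1 `N#CC1=C(NCC(=O)O)N(c2ccccc2)C(=O)N2CCCCC(N3CCCC3)C12` gives 81.7%. Compound 2 `N#CC1=C(NCC(=O)N2CCCC2)N(c2ccccc2)C(=O)N2CCCCC(N3CCCC3)C12` gives 49.8%, and compound 3 `COc1ccc(N/C=N/C2=C(C#N)C3C(N4CCCC4)CCCCN3C(=O)N2c2ccccc2)cc1` gives 37.2%. Compound 3 therefore stands lowest of the three, with compound 2 its nearest neighbour and compound 1 furthest away.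

The step to compound 4 `N#CC1=C(NCN2CCCCC2)N(c2ccccc2)C(=O)N2CCCCC(N3CCCC3)C12` is this: a group of 8 heavy atoms (6 carbon, 2 nitrogen; one six-membered non-aromatic ring with 1 hetero atom) in place of a group of 11 heavy atoms (8 carbon, 2 nitrogen, 1 oxygen; one six-membered aromatic ring of carbon only), on a double-bonded ring carbon. Going by the values given here, two measured steps bear on it, since both install the group that now leaves. The change a number 44.5 percentage points lower from compound 1 to compound 3 (beyond the scatter) and the change a number 12.6 percentage points lower from compound 2 to compound 3 (beyond the scatter) both point the same way: the group of 11 heavy atoms carrying the aromatic ring lowered the read-out each time it entered. Removing it in compound 4 is expected to reverse part of that loss, and the group that enters resembles the saturated ring amine of compound 2 more than anything in compound 3, so a rise toward the level of compound 2 is expected, estimated as a number 12.8 percentage points higher from compound 3 to compound 4 (beyond the scatter). Compound 4 is estimated at 50%, within a range of 30% to 70%.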

Compound 4, a percentage reported as inhibition, in the whole organism at one dose (the size of the read-out at that dose, not a potency): 36.9%
For compound 4 the middle estimate is 13.1 percentage points above the measured one, and the stated range covers the measured number.
By their numbers in this assay, from the lowest: compounds 4 and 3 (each within the scatter of the next); then compound 2; then compound 1.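

Putting ((piperidin-1-yl)methyl)amino in place of the group with the aromatic ring, on this double-bonded ring carbon, gives a number 0.3 percentage points lower from compound 3 to compound 4 (within the scatter) in this assay and so leaves the read-out unmoved: a carbon-only aromatic ring at the end of this substituent is not needed for compound 3 to sit at this level. The end of the chain still counts, since piperidin-1-yl in place of (pyrrolidin-1-yl)carbonyl gives a number 12.9 percentage points lower from compound 2 to compound 4 (beyond the scatter) and piperidin-1-yl in place of carboxy gives a number 44.8 percentage points lower from compound 1 to compound 4 (beyond the scatter) and so far only the carboxy group stands clearly apart. No measurement here gives a reason for these differences.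

Going by these compounds, it remains open whether a methyl ester would stay near compound 1 or fall to the level of the amide and amine groups. A longer chain carrying the carboxylic acid is equally untested in these data.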